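Working notes: replacing the large group of compound 2

The source may hold more compounds than are shown below. What is called first, only, known or untested is meant among the compounds shown, and "the series" means these compounds.

Among the compounds with values here, in a functional assay on HCT-116 cells (Homo sapiens) for inhibition, read by colorimetric assay, with a stated time of 3 days (on this read-out higher numbers stand for weaker inhibition and lower numbers for stronger inhibition), only two numbers exist so far. Compound 1 `O=C(CCCCCCNC(=O)C(O)(O)C(F)(F)F)Nc1nc2ccccc2o1` gives 3450 nM in this series. Compound 2 `Cc1ccc(S(=O)(=O)Nc2ccc(NC(=O)CCCCCCNC(=O)C(O)(O)C(F)(F)F)cc2)cc1` gives 17200 nM as the higher of the two numbers, beyond the scatter from compound 1, which makes it the weaker inhibitor of the pair. Compound 3 `O=C(CCCCCCNC(=O)C(O)(O)C(F)(F)F)Nc1ccc(Cl)cc1` is still unmeasured and differs from compound 2 by chloro in place of ((4-methylphenyl)sulfonyl)amino on an aromatic carbon with chloro in place of ((4-methylphenyl)sulfonyl)amino on an aromatic carbon. Within the data shown here, no measured pair isolates a change of this kind, so the guide is thin. Among the measured compounds shown here, compound 1 at 3450 nM is the only lower number to lean on, so a drop towards it is expected rather than a rise. Expected in this assay is a 2.9-fold lower number from compound 2 to compound 3 (0.46 log units; beyond the scatter) as an estimated move towards stronger inhibition, beyond the scatter. For compound 3 the estimate is 6000 nM with 2000 nM to 16000 nM as the expected range.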

Compound 3, half-maximal inhibitory concentration: 4230 nM
For compound 3 the middle estimate is 1.4-fold (0.15 log units) above the measured one, and the stated range covers the measured number.
By their numbers in this assay, from the lowest: compounds 1 and 3 (each within the scatter of the next); then compound 2.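

In this assay, chloro in place of ((4-methylphenyl)sulfonyl)amino on the aromatic carbon gives a 4.1-fold lower number from compound 2 to compound 3 (0.61 log units; beyond the scatter) and so shows that the large group, with its six-membered aromatic ring, is not required at this position for the inhibition seen here. The other step, a 1.2-fold higher number from compound 1 to compound 3 (0.09 log units; within the scatter) with 4-chlorophenyl in place of 1,3-benzoxazol-2-yl on the amide-type nitrogen, shows that this read-out does not separate these two groups. No supporting data are available to explain either step.

On these data alone, what an amine or a methoxy group would give on the same aromatic carbon stays open, and so does whether any group there goes beyond chloro. As far as these compounds go, the effect of a shorter or longer chain in the shared core also remains unknown.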